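This account rests on a few compounds, and the source may have more. Where it says the series, first, only, none or still open, it means among the compounds named here.

Measured compounds:
Compound 1, `CCC(c1ccc(O)c(OC)c1)c1cccc(O)c1O`, gives 90% in a functional assay for inhibition, with a stated time of 18 h, tested at 100 ug/mL; on this read-out higher numbers stand for more inhibition at the one concentration tested (going by the name of the read-out) and lower numbers for less inhibition.
Compound 2, `CCC(c1ccc(O)c(OC)c1)c1ccccc1O`, gives 90% in this assay.

Compound 2 stands level with compound 1 on these numbers: the step of no change at the digits printed from compound 1 to compound 2 (within the scatter) lies within the scatter, so removing the hydroxy group on the aromatic carbon left the read-out where it was. Compound 3, `CCC(c1ccc(O)c(OC)c1)c1cccc(C(C)C)c1O`, has not yet been measured in this assay. Compared with compound 2 the change is isopropyl in place of hydrogen on an aromatic carbon. Among the measured compounds shown here, no measured step shows what an isopropyl group does at this place; the only step known, from compound 1 to compound 2, touched the same ring and produced no change beyond the scatter. With both measured compounds near the top of the read-out, the account therefore expects a step of a number 2 percentage points lower from compound 2 to compound 3 (within the scatter), that is, nothing beyond the scatter. Compound 3 is accordingly estimated at 88%, with a range from 70% to 98%.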

Compound 3, a percentage reported as inhibition, at one concentration (the size of the read-out at that concentration, not a potency): 88%
Estimate against measurement, compound 3: no gap at the digits printed, within the range that was stated.
By their numbers in this assay, from the lowest: compounds 3, 1 and 2 (each within the scatter of the next).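

In this assay, the place ortho to a hydroxy group now carries isopropyl, a branched carbon group with no ring, and the step of a number 2 percentage points lower from compound 2 to compound 3 (within the scatter) lies within the scatter. Among the compounds shown here, the direct comparison with hydroxy at the same place, a number 2 percentage points lower from compound 1 to compound 3 (within the scatter), also lies within the scatter, so three groups now read level here, where the earlier compounds had covered only hydrogen and hydroxy. No independent measurement bears on why these groups read level.

All three compounds sit near the top of the read-out at a single concentration, so any difference in potency among them remains unresolved. Going by these compounds, whether an amine, a carboxylic acid or a longer chain at this place would also read level stays open, as does the contribution of the hydroxy group that all three compounds share on this ring.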